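The compounds below may be only part of what the source reports. "The series", "measured", "known", "first", "only" and "open" are said of these compounds alone.

Measured so far:
Compound 1, `Cc1ccc(Nc2c(NC(C)CCCCC(=O)NO)c(=O)c2=O)cc1`, gives in an ADME assay on cells (Hepatocyte, Homo sapiens) for pharmacokinetics, read by LC-MS, with a stated time of 90 min, tested at 1 uM (a lower number here means slower removal, a higher number faster removal of the compound), a reading that is only a limit of the assay, < 6.5 uL/min.
Compound 2, `COc1ccc(Nc2c(NC(C)CCCCC(=O)NO)c(=O)c2=O)cc1`, gives in this assay 7.1 uL/min.

Going by the values given here, compound 2 therefore stands as the only true number in this assay; the remaining reading is a limit. Among the compounds with values here, the single measured step, methoxy in place of methyl on an aromatic carbon, shows an at least 1.0-fold higher number from compound 1 to compound 2 (0.03 log units; that floor lies within the scatter), and with one side of it sitting at the limit of < 6.5 uL/min in this assay, at which 1 of the 2 values shown sits, it cannot be read as a real change in clearance.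

Compound 3, `CC(CCCCC(=O)NO)Nc1c(Nc2ccc(C(F)(F)F)cc2)c(=O)c1=O`, has not yet been measured. Its difference from compound 2 is trifluoromethyl in place of methoxy on an aromatic carbon. Within the data shown here, only that one measured step bears on it, and it gave no change beyond the scatter; nothing measured here tells a trifluoromethyl apart from a methoxy group, so no step beyond the scatter is expected either. The step from compound 2 to compound 3 is therefore expected to be a 1.0-fold lower number from compound 2 to compound 3 (0.01 log units; within the scatter). Compound 3 is estimated at 7 uL/min, with a likely range from 3 uL/min to 16 uL/min, while a reading that is again only a limit remains possible.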

Compound 3, intrinsic clearance in a liver preparation (reported as CLH), per the amount of preparation that the assay uses: 21 uL/min
Compound 3: middle estimate off by 3.0-fold (0.48 log units), on the low side, outside the stated range (above it).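

Methyl and methoxy could not be told apart at this position, but the aromatic carbon para to a large group now proves sensitive to the group placed on it: in this assay, trifluoromethyl in place of methoxy gives a 3.0-fold higher number from compound 2 to compound 3 (0.47 log units; beyond the scatter), the first step in this short series that is beyond the scatter. Trifluoromethyl in place of methyl points the same way, with an at least 3.2-fold higher number from compound 1 to compound 3 (0.50 log units; beyond the scatter), so trifluoromethyl goes with faster removal than either of the two smaller groups in this pair of comparisons. Compound 1 is only a limit, so the second step is a floor and its true size stays unknown: the limit of < 6.5 uL/min in this assay, at which 1 of the 3 values shown sits.

Three groups at one position cannot show what it is about trifluoromethyl that goes with the higher number, and they do not show whether the rise would continue or reverse with other groups. Going by these compounds, a chlorine atom, a nitrile or an amine on the same carbon would test whether this is particular to trifluoromethyl, while the effect of a shorter or longer chain on the other side of the core remains equally open.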